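The source may report more compounds than this note shows. Statements on the series, on what has been measured and on what is new or still open speak of the compounds shown alone.

In an assay on mitochondria (strain BALB/c) for inhibition of glycerol-3-phosphate acyltransferase 1, mitochondrial (Mus musculus), read by scintillation counting, with a stated time of 10 min (on this read-out lower numbers stand for stronger inhibition and higher numbers for weaker inhibition), compound 1 `CCCCCCCCS(=O)(=O)Nc1cc(-c2ccc(CCCC)cc2)ccc1C(=O)O` gives 15700 nM, the lower of the two numbers recorded so far. Compound 2 `CCCCCCCCS(=O)(=O)Nc1ccc(C(=O)c2ccc(OC)cc2)cc1C(=O)O` gives 44300 nM in the same assay, a higher number with a gap beyond the usual scatter. Compound 3 `CCCCCCCCS(=O)(=O)Nc1cc(CCc2ccccc2)ccc1C(=O)O` is not yet measured and differs from compound 1 in one place: phenethyl in place of 4-butylphenyl on an aromatic carbon. Among the compounds with values here, no measured pair shows this same change, so nothing in the data sets its size directly. For compound 3 the expected step of a 1.6-fold higher number from compound 1 to compound 3 (0.20 log units; within the scatter) is small, toward a higher number, and close to the scatter. Compound 3 is estimated at 25000 nM, with a range from 8000 nM to 80000 nM.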

Compound 3, half-maximal inhibitory concentration: 37500 nM
Estimate against measurement, compound 3: 1.5-fold (0.18 log units) below; measured number inside the range.
By their numbers in this assay, from the lowest: compound 1; then compounds 3 and 2 (each within the scatter of the next).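

On an aromatic carbon para to the carboxy group, phenethyl in place of 4-butylphenyl gives a 2.4-fold higher number from compound 1 to compound 3 (0.38 log units; beyond the scatter) in this assay, so this position responds to the group it carries. Both groups are all carbon, each with one six-membered aromatic ring and no hydrogen-bond donors or acceptors, so the step arises without any change in those counts. Nothing available explains the step.

Compound 3 changes both the link to the ring and the butyl tail, so their shares remain unseparated. A plain phenyl, a 4-butylphenethyl or an amine at this carbon would bear on that question.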